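Removing the Bromo Group from Compound 2

The source may hold more compounds than are shown below. What is called first, only, known or untested is meant among the compounds shown, and "the series" means these compounds.

Going by the values given here, compound 2 `O=C(Nc1ccc(Oc2ccnc3[nH]ccc23)cc1)c1nn(-c2ccc(Br)cc2)ccc1=O` holds the lowest of the two numbers so far in a functional assay on A549 cells (Homo sapiens) for cytotoxicity, read by MTT assay, with a stated time of 72 h (on this read-out lower numbers stand for stronger inhibition and higher numbers for weaker inhibition), where compound 2 gives 6240 nM. Compound 1 `COc1ccc(-n2ccc(=O)c(C(=O)Nc3ccc(Oc4ccnc5[nH]ccc45)cc3)n2)cc1` gives 53100 nM. Compound 3 `O=C(Nc1ccc(Oc2ccnc3[nH]ccc23)cc1)c1nn(-c2ccccc2)ccc1=O` differs from compound 2 by hydrogen in place of bromo on an aromatic carbon. Among the compounds with values here, no measured step removes a bromo outright; the only step that bears on it is an 8.5-fold lower number from compound 1 to compound 2 (0.93 log units; beyond the scatter), which showed a modest gain on putting bromo in the place of methoxy, so loss of the bromo is expected to raise the number moderately. Compound 3 is therefore estimated at 15000 nM, with a range of 5000 nM to 45000 nM, a step of a 2.4-fold higher number from compound 2 to compound 3 (0.38 log units; beyond the scatter).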

Compound 3, half-maximal inhibitory concentration: 10500 nM
For compound 3 the middle estimate is 1.4-fold (0.15 log units) above the measured one; the measured number falls inside the stated range.
By their numbers in this assay, from the lowest: compounds 2 and 3 (each within the scatter of the next); then compound 1.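

In this assay, taking the bromo away gives a 1.7-fold higher number from compound 2 to compound 3 (0.23 log units; within the scatter), so at this position the 4-bromophenyl and phenyl compounds cannot be told apart. Compound 3 without any substituent here still shows a 5.1-fold lower number from compound 1 to compound 3 (0.70 log units; beyond the scatter), which places the earlier gain on the methoxy of compound 1 being absent and not on the bromo being present. Nothing measured here accounts for this difference. From the compounds shown here alone, whether an amine or a hydroxy at this position would behave like the methoxy remains open, as does whether a chloro or a carboxylic acid would match hydrogen and bromo.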